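Aryl piperazine swap on the aminothiophene ketone series

This account rests on a few compounds, and the source may have more. Where it says the series, first, only, none or still open, it means among the compounds named here.

Measured so far in an assay on CHO cells for displacement of a labelled ligand from adenosine receptor A1 (Homo sapiens), read by scintillation counting, with a stated time of 120 min, tested at 10 uM; on this read-out higher numbers stand for more inhibition at the one concentration tested (going by the name of the read-out) and lower numbers for less inhibition:
compound 1 `Nc1scc(CN2CCN(c3ccc([N+](=O)[O-])cc3)CC2)c1C(=O)c1ccc(Cl)cc1`: 1%
compound 2 `Nc1scc(CN2CCN(c3ccc(C(F)(F)F)cc3)CC2)c1C(=O)c1cccc(C(F)(F)F)c1`: 0%

In this assay compound 1 gives 1% and compound 2 gives 0%; the two numbers lie within the usual scatter of each other, so no order is drawn between them. Compound 3 `Nc1scc(CN2CCN(c3cccc4ccccc34)CC2)c1C(=O)c1ccc(Cl)cc1` has not yet been measured. Its change from compound 1: naphthalen-1-yl in place of 4-nitrophenyl on an amine nitrogen in a ring. Within the data shown here, no step between measured compounds is available to guide this. Because compound 1 gives 1% in this assay, essentially no inhibition at the concentration tested, the expected step is a number 2 percentage points higher from compound 1 to compound 3 (within the scatter), none beyond the scatter. Compound 3 is therefore estimated at 3% in this assay, with a range from -8% to 15%.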

Compound 3, a percentage reported as inhibition, at one concentration (the size of the read-out at that concentration, not a potency): 1%
Estimate against measurement, compound 3: 2 percentage points above, and the stated range covers the measured number.
By their numbers in this assay, from the lowest: compounds 2, 1 and 3 (each within the scatter of the next).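

In this assay, naphthalen-1-yl in place of 4-nitrophenyl on the amine nitrogen in the ring gives no change at the digits printed from compound 1 to compound 3 (within the scatter). Among these compounds, this is the first single-place comparison at this position: a group with two six-membered aromatic rings of carbon only and no hydrogen-bond acceptors reads alike with 4-nitrophenyl, and compound 3 gives 1%. No measured evidence speaks to the reason for this result.

Open, from the compounds shown here alone, is whether a non-aryl group on this nitrogen, such as a carboxylic acid or a longer alkyl chain, would read differently. Going by these compounds, compound 2 differs from compound 1 in more than one place, so the separate contribution of each of its groups also stays open.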